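The compounds below may be only part of what the source reports. "The series", "measured", "known", "first", "only" and "open" are said of these compounds alone.

Measured so far in a functional assay on cardiac atrium for agonist activity at histamine H2 receptor (Cavia porcellus); on this read-out lower numbers stand for lower potency and higher numbers for higher potency (the scale is a negative logarithm):
compound 1 `N=C(NCCCc1c[nH]cn1)NCCC(c1ccc(Cl)cc1)c1ccccn1` gives 7.84
compound 2 `N=C(NCCCc1c[nH]cn1)NCCC(c1ccc(C(F)(F)F)cc1)c1ccccn1` gives 7.76
compound 3 `N=C(NCCCc1c[nH]cn1)NCCC(c1ccccn1)c1ccccc1F` gives 7.46

Compound 3 stands lowest of the three numbers in this assay: against compound 2 the gap is within the scatter, against compound 1 it lies beyond it (a number 0.38 log units lower from compound 1 to compound 3 (beyond the scatter)). The next compound, compound 4 `N=C(NCCCc1c[nH]cn1)NCCC(c1ccccn1)c1cccs1`, differs from compound 3 by thiophen-2-yl in place of 2-fluorophenyl on a saturated chain carbon bound to an aromatic carbon and a saturated chain carbon.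

Going by the values given here, two measured steps touch the same place: a number 0.38 log units lower from compound 1 to compound 3 (beyond the scatter) and a number 0.30 log units lower from compound 2 to compound 3 (within the scatter), both modest or within the scatter, showing that exchanging one aryl group for another at this chain carbon has so far moved the numbers little. Among the compounds with values here, no step shows a five-membered ring with a hetero atom entering here, so the thiophen-2-yl exchange has no direct precedent. The expectation is therefore a small step, most likely none beyond the scatter, with a wide range to cover the untested ring type; for compound 4 the estimate is 7.55 (range 7.05 to 8.05), which is expected to mean a step of a number 0.09 log units higher from compound 3 to compound 4 (within the scatter).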

Compound 4, negative logarithm of the half-maximal effective concentration: 7.16
Estimate against measurement, compound 4: 0.39 log units above; the measured number falls inside the stated range.
By their numbers in this assay, from the lowest: compounds 4, 3, 2 and 1 (each within the scatter of the next, the first and the last beyond it).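

In this assay, going by these compounds alone, thiophen-2-yl is the first five-membered aromatic ring with a hetero atom on this saturated chain carbon, and in place of 2-fluorophenyl it gives a number 0.30 log units lower from compound 3 to compound 4 (within the scatter), so this ring type is not separated from 2-fluorophenyl here. Against the two larger groups the picture differs: in place of 4-(trifluoromethyl)phenyl it gives a number 0.60 log units lower from compound 2 to compound 4 (beyond the scatter), and in place of 4-chlorophenyl it gives a number 0.68 log units lower from compound 1 to compound 4 (beyond the scatter), the widest step yet seen at this position, though still modest. No measurement at hand accounts for these steps.

The compounds shown do not separate ring size from the sulfur atom. A furan-2-yl group, or a phenyl ring carrying an amine or a carboxylic acid, on this chain carbon remains an open question.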